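The source may report more compounds than this note shows. Statements on the series, on what has been measured and on what is new or still open speak of the compounds shown alone.

Compound 1 `OC1CNCc2nc(-c3ccc(N4CCCC4)cc3)sc21`: 730 nM
Compound 2 `Cc1cc(N(C)C)ccc1-c1nc2c(s1)[C@H](O)CCC2`: 270 nM

Both compounds were tested in a functional assay on HCT-116 cells (Homo sapiens) for cytotoxicity, read by sulforhodamine B assay, with a stated time of 2 days; on this read-out lower numbers stand for stronger inhibition and higher numbers for weaker inhibition. Compound 2 gives 270 nM, the lower of the two numbers, while compound 1 gives 730 nM, and this gap lies beyond the usual scatter of repeated measurements.

The next compound to test is compound 3 `Cc1cc(N(C)C)ccc1-c1nc2c(s1)[C@@H](O)CCC2`. The change is the two compounds have the same atoms and bonds and differ only in configuration as drawn: 1 of 1 stereo elements differ; a stereocentre at a saturated ring carbon is drawn R in compound 2 and S in compound 3: the two compounds have the same atoms and bonds, and a stereocentre at a saturated ring carbon is drawn R in compound 2 and S in compound 3. For the measured compounds named here, nothing measured so far shows what such a switch does in this assay, so any forecast is loose. Going by the values given here, compound 2 holds the lowest number so far at 270 nM, which makes a move upward, towards weaker inhibition, the more likely direction. The expected change is a 2.2-fold higher number from compound 2 to compound 3 (0.35 log units; beyond the scatter), a modest step that could still prove to be none beyond the scatter. For compound 3 the estimated value is 600 nM, with an expected range of 130 nM to 3000 nM.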

Compound 3, half-maximal inhibitory concentration: 560 nM
Compound 3: the middle estimate sits 1.1-fold (0.03 log units) above what was measured; measured number inside the range.
By their numbers in this assay, from the lowest: compound 2; then compounds 3 and 1 (each within the scatter of the next).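

In this assay, redrawing the stereocentre at a saturated ring carbon from R to S gives a 2.1-fold higher number from compound 2 to compound 3 (0.32 log units; beyond the scatter), so the R form is the stronger of this pair. Compounds 1 and 2 could not show whether the spatial arrangement at this carbon matters at all, whereas this pair shows that it does, although the effect is modest and both forms still give a measurable number in this cell test. The gap can be assigned to this single stereocentre because nothing else separates the two compounds: the fact that compounds 2 and 3 differ only in the configuration as drawn

The compounds shown leave open whether the preference for R would hold with a different group at this stereocentre, such as an amine in place of the hydroxyl. They also leave open whether the same switch would shift the number in the same direction on a core carrying another aryl substituent, and why this cell test responds to the switch at all.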